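A few compounds are considered here, and "the series" means these few. Any claim that something is new, unique, unknown or untested is made for them only; others in the source may bear on it.

Compound 2 `O=S(=O)(c1ccc(F)cc1)c1cc(F)c(O)c2ncccc12` gives 15 uL/min in an ADME assay on cells (Hepatocyte, Rattus norvegicus) for pharmacokinetics; a higher number here means faster removal of the compound, a lower number slower removal. Among the compounds with values here, on the two numbers so far it stands within the scatter of compound 1 `O=S(=O)(c1ccc(C(F)(F)F)cc1)c1cc(F)c(O)c2ncccc12`, which in this assay gives 12 uL/min. Within the data shown here, the only measured step, a 1.3-fold higher number from compound 1 to compound 2 (0.10 log units; within the scatter), altered one group on an aromatic carbon and stayed within the scatter. Compound 3 `O=S(=O)(c1cc(F)c(O)c2ncccc12)C1CCCC1` differs from compound 2 by cyclopentyl in place of 4-fluorophenyl on a sulfonyl sulfur. Among the measured compounds shown here, no measured step bears directly on exchanging the ring on the sulfonyl sulfur, so the expected step of no change at the digits printed from compound 2 to compound 3 (within the scatter) is none beyond the scatter. Compound 3 is therefore estimated at 15 uL/min, within 7 uL/min to 35 uL/min.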

Compound 3, intrinsic clearance in a liver preparation (reported as CLH), per the amount of preparation that the assay uses: 19 uL/min
For compound 3 the middle estimate is 1.3-fold (0.10 log units) below the measured one, within the range that was stated.
By their numbers in this assay, from the lowest: compounds 1, 2 and 3 (each within the scatter of the next).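

Exchanging 4-fluorophenyl for cyclopentyl on the sulfonyl sulfur gave, in this assay, a 1.3-fold higher number from compound 2 to compound 3 (0.10 log units; within the scatter), which lies within the scatter. The earlier step changed only a group on an aromatic carbon, whereas this one shows that an aromatic ring on the sulfonyl sulfur can give way to a five-membered non-aromatic ring of carbon only without moving the number beyond the scatter. Nothing available explains this result. The compounds shown leave open whether an amine or a carboxylic acid on the cyclopentyl ring would move the number beyond the scatter.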